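This account rests on a few compounds, and the source may have more. Where it says the series, first, only, none or still open, it means among the compounds named here.

Working notes on the series. Compound 1 `C=CCn1c(=O)/c(=C\c2cccc(F)c2)[nH]c(=O)/c1=C\c1ccccc1OC` gives 8890 nM in a functional assay on HL-60 cells (Homo sapiens) for cytotoxicity, read by CCK-8 assay, with a stated time of 72 h (on this read-out lower numbers stand for stronger inhibition and higher numbers for weaker inhibition), the highest of the two numbers recorded; compound 2 `COc1ccccc1/C=c1\c(=O)[nH]/c(=C/c2ccccc2Cl)c(=O)n1C` gives 200 nM, and compound 3 `C=CCn1c(=O)/c(=C\c2cccc(Br)c2)[nH]c(=O)/c1=C\c1cccc(Br)c1` is recorded as "not active" (no number reported) without a number. The step of interest runs from compound 1 to compound 4 `C=CCn1c(=O)/c(=C\c2cccc(Cl)c2)[nH]c(=O)/c1=C\c1ccccc1OC`: chloro in place of fluoro on an aromatic carbon, on an aromatic carbon of a six-membered aromatic ring of carbon only. Within the data shown here, no measured pair shows this change, so nothing fixes its size. With compound 1 at 8890 nM as the only anchor, the expected step of a 1.5-fold lower number from compound 1 to compound 4 (0.17 log units; within the scatter) is small, if anything a move to a lower number, and may not exceed the scatter. Compound 4 is therefore estimated at 6000 nM, within 2000 nM to 20000 nM in this assay.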

Compound 4, half-maximal inhibitory concentration: 4500 nM
Compound 4: the middle estimate sits 1.3-fold (0.12 log units) above what was measured, within the range that was stated.
By their numbers in this assay, from the lowest: compound 2; then compounds 4 and 1 (each within the scatter of the next).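

The change from 3-fluorophenyl to 3-chlorophenyl on the core of compound 1 reads as a 2.0-fold lower number from compound 1 to compound 4 (0.30 log units; within the scatter) in this assay. This gives the series its first measured step at this position, and it shows that exchanging fluoro for chloro here stays within the scatter. Nothing measured on hand accounts for this step. From the compounds shown here alone, whether an amine, a nitrile or a carboxylic acid in this place would move the number beyond the scatter remains open. Also open, going by these compounds, is whether the same exchange behaves alike on a core other than that of compound 1.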